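The compounds below may be only part of what the source reports. "The series", "measured", "known", "first", "only" and "open" are said of these compounds alone.

Compound 1 `CCc1nc(C(=O)c2ccc(C)s2)c2sccc2n1`: 3670 nM
Compound 2 `CCNc1nc(C(=O)c2ccc(C)s2)c2sccc2n1`: 1260 nM
Compound 3 `Cc1ccc(C(=O)c2nc(NCc3ccccn3)nc3ccsc23)s1`: 43 nM

In a functional assay on CHO-K1 cells for antagonist activity at adenosine receptor A2b (Homo sapiens), read by FLIPR and calcium flux (on this read-out lower numbers stand for stronger inhibition and higher numbers for weaker inhibition), compound 3 holds the lowest of the three numbers, set apart from compound 2 by a 29-fold lower number from compound 2 to compound 3 (1.47 log units; beyond the scatter) and from compound 1 by an 85-fold lower number from compound 1 to compound 3 (1.93 log units; beyond the scatter). Compound 4 `Cc1ccc(C(=O)c2nc(NC(C)c3ccccn3)nc3ccsc23)s1` differs from compound 3 by methyl in place of hydrogen on a saturated chain carbon bound to an aromatic carbon and a nitrogen on an aromatic ring. None of the measured steps touches this saturated chain carbon: a 2.9-fold lower number from compound 1 to compound 2 (0.46 log units; beyond the scatter) and a 29-fold lower number from compound 2 to compound 3 (1.47 log units; beyond the scatter) both alter the group on the nitrogen of the aromatic ring, and the reading (pyridin-2-yl)methyl to 1-(pyridin-2-yl)ethyl has no precedent among these compounds. Compound 4 is therefore expected to show no step beyond the scatter, a 1.4-fold higher number from compound 3 to compound 4 (0.14 log units; within the scatter). The estimate for compound 4 is 60 nM, with a range from 20 nM to 200 nM.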

Compound 4, half-maximal inhibitory concentration: 19 nM
Beside the measured number, compound 4's estimate is 3.2-fold (0.50 log units) above it; measured number outside the range, below it.
By their numbers in this assay, from the lowest: compound 4; then compound 3; then compound 2; then compound 1.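

In this assay, within the data shown here, methyl in place of hydrogen on a saturated chain carbon bound to an aromatic carbon and a nitrogen on an aromatic ring gives a 2.3-fold lower number from compound 3 to compound 4 (0.35 log units; beyond the scatter), so this carbon, which no earlier step touched, also bears on the number. Pyridin-2-yl in place of hydrogen on this same carbon, starting from the ethylamino compound, gives a 66-fold lower number from compound 2 to compound 4 (1.82 log units; beyond the scatter). Nothing available here accounts for either step. The compounds shown leave open whether an ethyl or a cyclopropyl group on this carbon would lower the number further.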